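A few compounds are considered here, and "the series" means these few. Any claim that something is new, unique, unknown or untested is made for them only; others in the source may bear on it.

Measured compounds:
Compound 1 `O=S(=O)(Nc1ccc(-c2nc3ccccc3o2)cc1)c1ccc(Cl)s1`: in an assay on isolated protein for inhibition of malate dehydrogenase, mitochondrial (Sus scrofa), with stated times of 45 min and 30 min (a higher number here means a weaker inhibitor, a lower number a stronger inhibitor), compound 1 gives > 63000 nM, which is a limit of the assay and not a number.
Compound 2 `O=S(=O)(Nc1ccc(-c2nc3ccccc3o2)cc1)c1ccccc1Cl`: compound 2 gives > 63000 nM, again a limit.
Compound 3 `CS(=O)(=O)Nc1ccc(-c2nc3ccccc3o2)cc1`: compound 3 gives > 63000 nM, also a limit.

Compound 3 therefore stands at the limit, and it is not alone there: the limit of > 63000 nM in this assay, at which 3 of the 3 values shown sit. Every measured step in this series changes the group on the sulfonyl sulfur, and none of them can be read. The step that the two limits leave unreadable from compound 1 to compound 2, the step that the two limits leave unreadable from compound 1 to compound 3 and the step that the two limits leave unreadable from compound 2 to compound 3 are all hidden between two limits, so nothing in the measured data shows that any exchange at this position moves the readout.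

Compound 4 `C=Cc1ccc(S(=O)(=O)Nc2ccc(-c3nc4ccccc4o3)cc2)cc1` differs from compound 3 in the same place: 4-vinylphenyl in place of methyl on a sulfonyl sulfur. The three measured steps bear on this change in the sense that they cover the same position, but since their sizes are not readable they give no direction for this assay. No step beyond the scatter is therefore expected, and compound 4 is expected to remain at the limit.

The estimate for compound 4 in this assay is 90000 nM, with a range from 20000 nM to 400000 nM, meaning an expected step that the limit leaves unreadable from compound 3 to compound 4.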

Compound 4, half-maximal inhibitory concentration: > 63000 nM
Compound 4: no number, only a limit; the forecaster's own chance of this, stated with the estimate: 80%; the middle value is on the limit's open side.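

Compound 4 gives > 63000 nM in this assay as a limit of the assay and not a number. No new step can be read, since the steps joining compound 4 to compound 1, compound 2 and compound 3 all remain hidden between limits: the limit of > 63000 nM in this assay, at which 4 of the 4 values shown sit. The compounds shown leave open whether any group on the sulfonyl sulfur changes the result in this assay at all.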